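The compounds below may be only part of what the source reports. "The series", "measured", "known", "first", "only" and "open" are said of these compounds alone.

Three compounds share one core and differ only in the substituents on the outer aromatic ring. Compound 1 `CNC(=O)c1ccc(Oc2cccc(NC(=S)Nc3ccc(Br)c(C(F)(F)F)c3)c2)nc1` gives 2670 nM in a functional assay on PC-3 cells (Homo sapiens) for antiproliferative activity, read by MTT assay; on this read-out lower numbers stand for stronger inhibition and higher numbers for weaker inhibition. Compound 2 `CNC(=O)c1ccc(Oc2cccc(NC(=S)Nc3ccc(F)cc3)c2)nc1` gives 32700 nM in this assay. Compound 3 `CNC(=O)c1ccc(Oc2cccc(NC(=S)Nc3ccc(F)c(C(F)(F)F)c3)c2)nc1` gives 7950 nM in this assay, which places it second highest of the three numbers: the step of a 3.0-fold higher number from compound 1 to compound 3 (0.47 log units; beyond the scatter) separates it from compound 1, and the step of a 4.1-fold lower number from compound 2 to compound 3 (0.61 log units; beyond the scatter) separates it from compound 2.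

Compound 4 `CNC(=O)c1ccc(Oc2cccc(NC(=S)Nc3ccc(Cl)c(C(F)(F)F)c3)c2)nc1` is the next compound. The change from compound 3 is chloro in place of fluoro on an aromatic carbon. Within the data shown here, only one measured step bears on this change, a 3.0-fold higher number from compound 1 to compound 3 (0.47 log units; beyond the scatter), where exchanging bromo for fluoro on the same aromatic carbon raised the number modestly. Chloro is a third halogen at that carbon, and the data hold no direct chloro comparison; the expectation is therefore that compound 4 lands between compound 1 and compound 3, with the step of a 1.8-fold lower number from compound 3 to compound 4 (0.25 log units; within the scatter) expected to be modest and downward. Compound 4 is estimated at 4500 nM in this assay, with a likely range from 2000 nM to 10000 nM.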

Compound 4, half-maximal inhibitory concentration: 1980 nM
Estimate against measurement, compound 4: 2.3-fold (0.36 log units) above; measured number below the stated range.
By their numbers in this assay, from the lowest: compounds 4 and 1 (each within the scatter of the next); then compound 3; then compound 2.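

With chloro on this carbon, ortho to the trifluoromethyl group, the step of a 4.0-fold lower number from compound 3 to compound 4 (0.60 log units; beyond the scatter) shows that the exchange of fluoro for a larger halogen can be read in both directions of the series, not only through bromo, and that chloro is enough to produce a shift of that size in this assay. Among these compounds, the step of a 1.3-fold lower number from compound 1 to compound 4 (0.13 log units; within the scatter) adds what the earlier compounds could not show: chloro and bromo cannot be told apart here, so among the three halogens at this carbon, fluoro alone stands apart, with compound 3 separated from both compound 1 and compound 4 by more than the usual scatter. Nothing available here gives a measured reason why fluoro behaves differently from the other two halogens at this carbon.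

The compounds shown leave open how a methoxy group, an amine or a nitrile at this carbon would compare with the halogens, and whether plain hydrogen there, with the trifluoromethyl group kept, would hold up as well. They also leave open whether the gain from adding trifluoromethyl, seen with fluoro in the step of a 4.1-fold lower number from compound 2 to compound 3 (0.61 log units; beyond the scatter), would be of similar size with chloro on the ring.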